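The source may hold more compounds than are shown below. What is called first, only, known or untested is meant among the compounds shown, and "the series" means these compounds.

The compounds share one core carrying two benzyl ethers, and all were examined in a functional assay on CFPAC-1 cells (Homo sapiens) for antiproliferative activity, read by MTT assay, with a stated time of 72 h; on this read-out lower numbers stand for stronger inhibition and higher numbers for weaker inhibition. Compound 1 `O=C1O/C(=C\Cn2cc(-c3cc(F)cc(F)c3)nn2)C(OCc2ccccc2)=C1OCc1ccccc1` was recorded there as "not active" (no number reported), with no number given. Compound 2 `Cc1ccc(-c2cn(C/C=C3\OC(=O)C(OCc4ccccc4)=C3OCc3ccccc3)nn2)cc1` is reported in this assay as > 100000 nM, which is a limit of the assay and not a number. Among the measured compounds shown here, compound 3 `O=C1O[C@H]([C@@H](O)Cn2cc(CNS(=O)(=O)c3ccc(Cl)cc3F)nn2)C(OCc2ccccc2)=C1OCc1ccccc1` gives 58200 nM in this assay, the only single number in the set. Compound 2 therefore stands at the limit of > 100000 nM in this assay, at which 1 of the 3 values shown sits, with compound 1 the one further entry that lacks a number.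

The unmeasured compound 4 `O=C1O/C(=C\Cn2cc(-c3cccc(O)c3)nn2)C(OCc2ccccc2)=C1OCc1ccccc1` differs from compound 2 in one place: 3-hydroxyphenyl in place of 4-methylphenyl on an aromatic carbon. For the measured compounds named here, no step between two measured compounds is available to gauge what such a change does in this assay, and the one numbered value of the set is itself weak. The step expected from compound 2 to compound 4 is therefore an at least 1.1-fold lower number from compound 2 to compound 4 (0.04 log units; that floor lies within the scatter), which is not expected to exceed the scatter. Compound 4 is estimated at 90000 nM in this assay, within a range from 30000 nM to 300000 nM, and a further limit-only result would not surprise.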

Compound 4, half-maximal inhibitory concentration: 33700 nM
Compound 4: the middle estimate sits 2.7-fold (0.43 log units) above what was measured; the range from low to high includes it.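

In this assay, the aromatic carbon of the five-membered aromatic ring with 3 nitrogen now shows a first readable response: 3-hydroxyphenyl in place of 4-methylphenyl gives an at least 2.9-fold lower number from compound 2 to compound 4 (0.47 log units; beyond the scatter). Both groups hold 7 heavy atoms, and the entering one brings 1 hydrogen-bond donor and 1 hydrogen-bond acceptor, so the step comes with no change in heavy-atom count. Compound 2 stands at a limit of the assay and not at a number, so the step is a floor and its true size stays unknown: the limit of > 100000 nM in this assay, at which 1 of the 4 values shown sits.

The compounds shown do not separate the effect of the hydroxyl from that of its place on the ring or from the loss of the methyl. They also leave open how a methoxy group or an amine would read at this position.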